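The source may report more compounds than this note shows. Statements on the series, on what has been measured and on what is new or still open speak of the compounds shown alone.

Compound 2 `CCCC[C@]1(CC)CS(=O)(=O)c2ccc(OC)cc2[C@@H](c2ccccc2)[C@H]1O` belongs to a small set of sulfone-bearing compounds that share one core and differ only in one group on the aromatic ring. In an assay on cells for inhibition of ileal sodium/bile acid cotransporter (Homo sapiens) (a lower number here means a stronger inhibitor, a higher number a weaker inhibitor), compound 2 gives 55 nM. Among the three measured numbers this is the second highest. Its nearest neighbour is compound 1 `CCCC[C@]1(CC)CS(=O)(=O)c2ccc(Br)cc2[C@@H](c2cccc(OC)c2)[C@H]1O`, which gives 70 nM, a difference within the usual scatter. Furthest from it is compound 3 `CCCC[C@]1(CC)CS(=O)(=O)c2ccc(N(C)C)cc2[C@@H](c2ccccc2)[C@H]1O`, which gives 5 nM; that step, an 11-fold lower number from compound 2 to compound 3 (1.04 log units; beyond the scatter), came from putting dimethylamino in place of methoxy on an aromatic carbon.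

Compound 4 `CCCC[C@]1(CC)CS(=O)(=O)c2ccc(NC(C)=O)cc2[C@@H](c2ccccc2)[C@H]1O` is not yet measured. It differs from compound 2 in one place: acetamido in place of methoxy on an aromatic carbon. Going by the values given here, the only measured step that bears on this change is the one from compound 2 to compound 3, where exchanging the methoxy for a nitrogen-bearing group at the same aromatic carbon gave a large gain. Acetamido is also a nitrogen-bearing group, yet not the same one, so a gain is expected, although a smaller and less certain one. The expected step is a 1.8-fold lower number from compound 2 to compound 4 (0.26 log units; within the scatter). For compound 4 the estimate in this assay is 30 nM, within a range of 8 nM to 110 nM.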

Compound 4, half-maximal inhibitory concentration: 90 nM
Compound 4: the middle estimate sits 3.0-fold (0.48 log units) below what was measured, and the stated range covers the measured number.
By their numbers in this assay, from the lowest: compound 3; then compounds 2, 1 and 4 (each within the scatter of the next).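

In this assay the exchange of methoxy for acetamido gives a 1.6-fold higher number from compound 2 to compound 4 (0.21 log units; within the scatter) and so cannot be told apart from no change at all. A nitrogen on this aromatic carbon is therefore not enough to give the strong inhibition of compound 3: the step to the other nitrogen-bearing group gives an 18-fold higher number from compound 3 to compound 4 (1.26 log units; beyond the scatter) and is large, which shows that what is attached to that nitrogen matters. No measurement here explains why these two groups differ so widely.

The compounds shown hold only dimethylamino and acetamido as nitrogen-bearing groups at this position. On these data alone, it remains open how a plain amine or a methylamino group would compare, and whether a urea or an amide with a longer chain would behave like acetamido.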